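A few compounds are considered here, and "the series" means these few. Any claim that something is new, unique, unknown or untested is made for them only; others in the source may bear on it.

For the measured compounds named here, compound 1, with the structure `CC1(C)Nc2c(ccc(C(=O)c3ccccc3)c2O)OC1NC1CCCCC1`, gives 29 uM in a functional assay on HT-22 cells (Mus musculus), read by MTT assay; on this read-out higher numbers stand for lower toxicity in this test and lower numbers for higher toxicity in this test; that is the only plain number here. Compound 2, `CN(CC1OCCO1)C1Oc2ccc(C(=O)c3ccccc3)c(O)c2NC1c1ccccc1`, reaches only a limit of the assay, > 250 uM. The other value on record is thus (the limit of > 250 uM in this assay, at which 1 of the 2 values shown sits). Compound 3, `CC1(C)Nc2c(ccc(C(=O)c3ccccc3)c2O)OC1O`, has not yet been measured. Compared with compound 1 it carries hydroxy in place of cyclohexylamino on a saturated ring carbon. Going by the values given here, no measured pair shares this change, so the expected step from compound 1 to compound 3, a 3.1-fold higher number from compound 1 to compound 3 (0.49 log units; beyond the scatter), is a modest rise beyond the scatter, toward lower toxicity. Compound 3 is estimated at 90 uM, within 30 uM to 250 uM.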

Compound 3, half-maximal toxic concentration: 48 uM
Compound 3: middle estimate off by 1.9-fold (0.27 log units), on the high side; low and high end bracket the measured number.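

At this saturated ring carbon, hydroxy in place of cyclohexylamino gives a 1.7-fold higher number from compound 1 to compound 3 (0.22 log units; within the scatter) in this assay. For the compounds shown here, the large carbon ring of cyclohexylamino can therefore be replaced by a single oxygen-bearing group with no change in this test that stands out from repeat variation, something no earlier pair could show. No measurement at hand gives a reason for this result.

Still open, on these data alone, is how a methoxy group, a simple primary amine or a longer alkyl chain on this carbon would read. As far as these compounds go, whether any group here shifts toxicity beyond the scatter also remains unknown.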